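A few compounds are considered here, and "the series" means these few. Any claim that something is new, unique, unknown or untested is made for them only; others in the source may bear on it.

Compounds 1 to 3 share one core and differ only in the group on the aromatic nitrogen. Compound 1 `O=C1c2c[n+]([O-])c3ccccc3c2C(=O)c2c1c1ccccc1n2Cc1cn(C[C@@H](O)CO)nn1` reaches in a functional assay on SH-SY5Y cells (Homo sapiens) for cytotoxicity, read by MTT assay, with a stated time of 72 h (a lower number here means a stronger inhibitor, a higher number a weaker inhibitor), only a limit, > 500 nM. Compound 2 `CN(C)CCCCn1c2c(c3ccccc31)C(=O)c1c[n+]([O-])c3ccccc3c1C2=O` gives 250 nM in this assay, and compound 3 `CN1CCN(CCCCn2c3c(c4ccccc42)C(=O)c2c[n+]([O-])c4ccccc4c2C3=O)CC1` gives 100 nM, the lowest of the two numbers shown. The gap between them is a 2.5-fold lower number from compound 2 to compound 3 (0.40 log units; beyond the scatter), a modest step. Compound 4 `O=C1c2c[n+]([O-])c3ccccc3c2C(=O)c2c1c1ccccc1n2CCN1CCCCC1` differs from compound 3 by piperidin-1-yl in place of 2-(4-methylpiperazin-1-yl)ethyl on a saturated chain carbon, two bonds along the chain from an aromatic nitrogen. The step from compound 2 to compound 3 is the only measured one that bears on this change, and it was modest. Compound 4 is therefore expected to move back toward compound 2, a modest rise in number, a 2.5-fold higher number from compound 3 to compound 4 (0.40 log units; beyond the scatter). Compound 4 is estimated at 250 nM, with a range from 100 nM to 600 nM.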

Compound 4, half-maximal inhibitory concentration: 1860 nM
Estimate against measurement, compound 4: 7.4-fold (0.87 log units) below; the measured number lies above the stated range.
By their numbers in this assay, from the lowest: compound 3; then compound 2; then compound 4.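

In this assay, among the compounds shown here, the group on the aromatic nitrogen matters more than the earlier compounds suggested: there is a 19-fold higher number from compound 3 to compound 4 (1.27 log units; beyond the scatter), and a 7.4-fold higher number from compound 2 to compound 4 (0.87 log units; beyond the scatter). The 2-(piperidin-1-yl)ethyl group of compound 4 has both a shorter chain and a different amine, and together these changes raise the number well past the modest step seen when only the amine changed. The step from compound 1 to compound 4 cannot be read: the limit of > 500 nM in this assay, at which 1 of the 4 values shown sits. Chain and amine therefore remain tangled here. A 4-(piperidin-1-yl)butyl or 2-(4-methylpiperazin-1-yl)ethyl group on the shared core would separate them.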